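A few compounds are considered here, and "the series" means these few. Any claim that something is new, unique, unknown or untested is made for them only; others in the source may bear on it.

In a functional assay on VCaP cells (Homo sapiens) for antiproliferative activity, read by CCK-8 assay, with a stated time of 6 days (on this read-out higher numbers stand for weaker inhibition and lower numbers for stronger inhibition), compound 1 `CCN(c1ccc(C#N)c(Cl)c1)c1cc(-c2cnc3ccccc3c2)ccc1C` gives 25300 nM and compound 2 `CCN(c1ccc(C#N)c(Cl)c1)c1cc(-c2cncnc2)ccc1C` gives 3920 nM as its value. For compound 3 `CCN(c1cccc(-n2ccnc2)c1)c1ccc(C#N)c(C(F)(F)F)c1` the reading > 30000 nM is a limit and not a number. As far as these compounds go, its exact place on the scale therefore stays open.

Compound 4 `CCN(c1ccc(C#N)c(C(F)(F)F)c1)c1cc(-n2ccnc2)ccc1C` comes from compound 3 through a single change, methyl in place of hydrogen on an aromatic carbon and nothing else. For the measured compounds named here, no measured pair shows this change on its own, so any forecast is rough. Compound 1 carries this methyl and reads 25300 nM in this assay while compound 2 also carries it and reads 3920 nM as a number, though both differ from compound 4 elsewhere too. On that basis, a moderate move towards stronger inhibition is expected. The estimated step is an at least 3.0-fold lower number from compound 3 to compound 4 (0.47 log units; beyond the scatter) and remains uncertain. For compound 4 the expected value is 10000 nM with an estimated range from 3000 nM to 30000 nM in this test.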

Compound 4, half-maximal inhibitory concentration: >= 3920 nM
Compound 4: a limit, no number; the forecaster's own chance of this, stated with the estimate: 25%; the middle value is on the limit's open side.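

Compound 3 and compound 4 are both known only as limits in this assay, and no step can be read between them. The compounds shown leave open whether methyl in place of hydrogen on an aromatic carbon changes inhibition, and in which direction.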